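Replacing the isobutyl end of compound 2

The source may report more compounds than this note shows. Statements on the series, on what has been measured and on what is new or still open speak of the compounds shown alone.

Measured in an ADME assay on liver (Homo sapiens) for metabolic stability, read by LC-MS, using microsomes and NADPH, with a stated time of 15 min, tested at 1 uM (on this read-out higher numbers stand for fast clearance and lower numbers for slow clearance), so far:
Compound 1 `C[C@@H]1CN(Cc2ccccc2)c2nc(C(F)(F)F)ccc2[C@H](C)N1C(=O)NCc1ccccc1` gives 531 mL.min-1.g-1
Compound 2 `COc1ccc(CNC(=O)N2[C@H](C)CN(CCC(C)C)c3cnccc3[C@@H]2C)cc1` gives 94 mL.min-1.g-1

Compound 2 holds the lower of the two numbers in this short series, with 94 mL.min-1.g-1, while compound 1 gives 531 mL.min-1.g-1. The gap between these two compounds lies beyond the usual scatter. Compound 3 `COc1ccc(CNC(=O)N2[C@H](C)CN(Cc3ccc(C(F)(F)F)o3)c3cnccc3[C@@H]2C)cc1` carries 5-(trifluoromethyl)furan-2-yl in place of isobutyl on a saturated chain carbon bound to a nitrogen on an aromatic ring in a ring, a change counted as 5-(trifluoromethyl)furan-2-yl in place of isobutyl on a saturated chain carbon bound to a nitrogen on an aromatic ring in a ring in full. For the measured compounds named here, no measured pair isolates this change, so the expectation is tentative. A modest rise in this assay is expected, and it may stay within the scatter. The estimated step is a 1.6-fold higher number from compound 2 to compound 3 (0.20 log units; within the scatter) and its direction remains uncertain. For compound 3 the estimated value is 150 mL.min-1.g-1 with an expected range from 60 mL.min-1.g-1 to 400 mL.min-1.g-1 in this measurement.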

Compound 3, intrinsic clearance in microsomes: 119 mL.min-1.g-1
Estimate against measurement, compound 3: 1.3-fold (0.10 log units) above; the measured number falls inside the stated range.
By their numbers in this assay, from the lowest: compounds 2 and 3 (each within the scatter of the next); then compound 1.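

At the position on a saturated chain carbon bound to a nitrogen on an aromatic ring in a ring, this assay now has its first comparison that differs in one place: 5-(trifluoromethyl)furan-2-yl in place of isobutyl gives a 1.3-fold higher number from compound 2 to compound 3 (0.10 log units; within the scatter). At this position, then, the read-out does not separate an open isobutyl end from a larger group with a five-membered aromatic ring and a trifluoromethyl substituent. Nothing at hand explains why these two groups read alike.

As far as these compounds go, it remains open whether an amine, a carboxylic acid or a longer alkyl chain at this place would give a number beyond the scatter. Compound 1 differs from compound 2 and compound 3 in more than one place, so it cannot show whether the furan ring or its trifluoromethyl group matters more.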